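Swapping an amide for a sulfoxide on the outer ring

The compounds below may be only part of what the source reports. "The series", "measured", "known", "first", "only" and "open" are said of these compounds alone.

Measured so far:
- Compound 1, `CN(C)C(=O)c1cccc(C#Cc2cc(Cl)ccc2OCC(=O)O)c1`, in an assay on CHO cells for displacement of a labelled ligand from prostaglandin D2 receptor 2 (Homo sapiens), read by scintillation counting (a lower number here means a stronger inhibitor, a higher number a weaker inhibitor), gives 52 nM.
- Compound 2, `CC(C)(C)N1C(=O)c2ccc(C#Cc3cc(Cl)ccc3OCC(=O)O)cc2S1(=O)=O`, in this assay gives 14 nM.

For the measured compounds named here, of these two numbers, compound 1 carries the higher one, so it is the weaker binder of the pair; the number for compound 2 is lower by a gap beyond the usual scatter, though no single-point step between them is defined.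

Compound 3, `C[S+]([O-])c1cccc(C#Cc2cc(Cl)ccc2OCC(=O)O)c1`, has not yet been measured. It differs from compound 1 in one place: a group of 3 heavy atoms (1 carbon, 1 oxygen, 1 sulfur; no ring) in place of a group of 5 heavy atoms (3 carbon, 1 nitrogen, 1 oxygen; no ring), on an aromatic carbon, so that a group of 3 heavy atoms (1 carbon, 1 oxygen, 1 sulfur; no ring) takes the place of a group of 5 heavy atoms (3 carbon, 1 nitrogen, 1 oxygen; no ring), on an aromatic carbon. Going by the values given here, no measured pair shows the effect of this change, so the expected step in this assay is small, most likely within the scatter or a modest rise. Compound 3 is therefore estimated at 80 nM, with a range of 25 nM to 250 nM, an expected step of a 1.5-fold higher number from compound 1 to compound 3 (0.19 log units; within the scatter).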

Compound 3, inhibition constant: 3.2 nM
Beside the measured number, compound 3's estimate is 25-fold (1.40 log units) above it; the whole stated range lies above it.
By their numbers in this assay, from the lowest: compound 3; then compound 2; then compound 1.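

In this assay, replacing the dimethylcarbamoyl group with a methyl sulfoxide gives a 16-fold lower number from compound 1 to compound 3 (1.21 log units; beyond the scatter). This shows that the dimethylcarbamoyl group is not required for strong binding in this series, and that a group of 3 heavy atoms can far outperform the group of 5 heavy atoms it replaces. It also shows that the choice of group on this aromatic carbon, meta to a large group, has a large effect on the measured number, even with the rest of the molecule unchanged.

Still open, as far as these compounds go, is how a methyl thioether, with no oxygen on the sulfur, or a methyl sulfone, with two, would compare, and whether a longer chain on the sulfur would be tolerated. The results shown include no measurement that accounts for the gain.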